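A few compounds are considered here, and "the series" means these few. Any claim that something is new, unique, unknown or untested is made for them only; others in the source may bear on it.

Compound 1 `Cc1ccc(-c2nc3ncccc3o2)cc1` gives 5% in a functional assay on the whole organism for inhibition, with Rattus norvegicus as the target, at a dose of 30 mg/kg; on this read-out higher numbers stand for more inhibition at the one dose given (going by the name of the read-out) and lower numbers for less inhibition.
Compound 2 `N#Cc1cccc(-c2nc3ncccc3o2)c1` gives 21% in this assay.
Compound 3 `O=[N+]([O-])c1cccc(-c2nc3ncccc3o2)c1` gives 21% in this assay.

Compound 3 stands level with compound 2, and the two together hold the highest of the three numbers; compound 1 lies a good way lower, beyond the scatter. Among the measured compounds shown here, the only step between measured compounds that differ in one place runs no change at the digits printed from compound 2 to compound 3 (within the scatter), and it lies within the scatter. Compound 4 `c1ccc(-c2nc3ncccc3o2)cc1` differs from compound 3 in this way: hydrogen in place of nitro on an aromatic carbon. For the measured compounds named here, no measured step replaces a group by hydrogen, so the one known step does not bear directly on this change; it shows only that exchanging nitro for cyano leaves the read-out unmoved, while compound 1, carrying a methyl, gives a lower number. The step from compound 3 to compound 4 is therefore expected to be a number 9 percentage points lower from compound 3 to compound 4 (within the scatter), downward but uncertain. Compound 4 is expected to give about 12% in this assay, between 0% and 26%.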

Compound 4, a percentage reported as inhibition, in the whole organism at one dose (the size of the read-out at that dose, not a potency): 41%
Estimate against measurement, compound 4: 29 percentage points below; the measured number lies above the stated range.
By their numbers in this assay, from the lowest: compound 1; then compounds 2 and 3 (each within the scatter of the next); then compound 4.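

In this assay the ring without a substituent in compound 4 stands above all three compounds that carry a group, with a number 20 percentage points higher from compound 3 to compound 4 (beyond the scatter) and a number 20 percentage points higher from compound 2 to compound 4 (beyond the scatter) and also a number 36 percentage points higher from compound 1 to compound 4 (beyond the scatter) as the steps. The earlier compounds shown here all carried a group on this six-membered aromatic ring, so they could not show that hydrogen gives a higher number than nitro, cyano or methyl. Among the four compounds shown, none goes against this, although it holds for these three groups alone.

Going by these compounds, whether any other group on this carbon could match hydrogen stays open, and a fluorine, a methoxy or an amine would test that. Nothing given here explains why hydrogen gives the higher number.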